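The source may report more compounds than this note shows. Statements on the series, on what has been measured and on what is new or still open speak of the compounds shown alone.

- Compound 1 `COc1ccc(C(=O)N2N=C(C)CC2c2ccccc2O)cc1`: 38500 nM
- Compound 2 `CC1=NN(S(=O)(=O)c2ccccc2)C(c2cc(Br)ccc2O)C1`: > 60000 nM (a limit of the assay)
- Compound 3 `CC1=NN(S(=O)(=O)c2ccccc2C)C(c2cc(Br)ccc2O)C1`: > 60000 nM (a limit of the assay)

These values come from a functional assay on MGC-803 cells (Homo sapiens) for antiproliferative activity, read by MTT assay, with a stated time of 48 h; on this read-out lower numbers stand for an effect already at smaller amounts and higher numbers for an effect only at larger amounts of compound. Compound 2 gives no number, and it sits at the limit of > 60000 nM in this assay, at which 2 of the 3 values shown sit. Compound 4 `CC1=NN(S(=O)(=O)c2ccc([N+](=O)[O-])cc2)C(c2cc(Br)ccc2O)C1` differs from it by one change: nitro in place of hydrogen on an aromatic carbon, on a six-membered aromatic ring of carbon only, para to a large group.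

Within the data shown here, the one measured step of this kind is a step that the two limits leave unreadable from compound 2 to compound 3, with methyl in place of hydrogen on an aromatic carbon. It offers no size to carry over. Among the measured compounds shown here, the only number in this set belongs to compound 1, which carries a different substitution pattern, at 38500 nM. The data therefore support no expected step beyond the scatter in this assay, and no direction for one. The expected change is a number no higher from compound 2 to compound 4 (the limit leaves the size open), and it is only an estimate. Compound 4 is estimated at 60000 nM, with an expected range from 25000 nM to 120000 nM.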

Compound 4, half-maximal effective concentration: 22200 nM
The estimate for compound 4 lay 2.7-fold (0.43 log units) above the measured number; the whole stated range lies above it.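

In this assay, nitro in place of hydrogen on an aromatic carbon, para to a large group, gives an at least 2.7-fold lower number from compound 2 to compound 4 (0.43 log units; beyond the scatter). Among these compounds, the methyl step from the earlier pair cannot be read, so this is the first sign that a change on this six-membered aromatic ring can move the number at all, and the direction is towards an effect at smaller amounts. The true size of the step stays open because compound 2 gives only a limit of the assay: the limit of > 60000 nM in this assay, at which 2 of the 4 values shown sit.

From the compounds shown here alone, what an amine or a carboxylic acid would do at this same place remains open. So does whether the step is specific to nitro or would also follow from another group there, since a single readable step cannot separate the two.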